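The source may report more compounds than this note shows. Statements on the series, on what has been measured and on what is new or still open speak of the compounds shown alone.

Measured so far:
Compound 1, `Nc1nc(N2CCN(C(=O)COc3ccc(Cl)cc3)CC2)c2nc(-c3ccc(F)cc3)sc2n1`: in a functional assay on cells (Lymphocyte, Homo sapiens) (a higher number here means a weaker inhibitor, a lower number a stronger inhibitor), compound 1 gives 490 nM.
Compound 2, `Cc1cccc(N2CCN(c3nc(N)nc4sc(-c5ccc(F)cc5)nc34)CC2)c1`: compound 2 gives > 10000 nM.

The value of compound 2 is a limit of this assay, not a number; compound 2 sits at the limit of > 10000 nM in this assay, at which 1 of the 2 values shown sits. For the measured compounds named here, the only measured step connects these two compounds: an at least 20-fold higher number from compound 1 to compound 2 (1.30 log units; beyond the scatter). Compound 3, `Nc1nc(N2CCN(C(=O)COc3ccc(Br)cc3)CC2)c2nc(-c3ccc(F)cc3)sc2n1`, has not yet been measured. It differs from compound 2 in one place: ((4-bromophenoxy)methyl)carbonyl in place of 3-methylphenyl on an amine nitrogen in a ring. This change runs the measured step backwards, since the ((4-bromophenoxy)methyl)carbonyl entering in compound 3 closely resembles the ((4-chlorophenoxy)methyl)carbonyl that compound 1 carries. Because the step of an at least 20-fold higher number from compound 1 to compound 2 (1.30 log units; beyond the scatter) was large, the reverse change is expected to bring the number down by a similarly large amount, from the limit back into the measurable range, while the bromine-for-chlorine difference is expected to move it little. Compound 3 is therefore expected to give about 450 nM in this assay, within a range of 150 nM to 1500 nM. That estimate corresponds to an expected step of an at least 22-fold lower number from compound 2 to compound 3 (1.34 log units; beyond the scatter).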

Compound 3, half-maximal inhibitory concentration: 380 nM
Beside the measured number, compound 3's estimate is 1.2-fold (0.07 log units) above it, within the range that was stated.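

In this assay, placing ((4-bromophenoxy)methyl)carbonyl on the amine nitrogen in place of 3-methylphenyl gives an at least 26-fold lower number from compound 2 to compound 3 (1.42 log units; beyond the scatter), so a second group of this kind brings the number back into the measurable range, which until now only compound 1 had shown. The value of compound 2 is a limit and not a number: the limit of > 10000 nM in this assay, at which 1 of the 3 values shown sits.
Exchanging chloro for bromo on the aromatic carbon gives a 1.3-fold lower number from compound 1 to compound 3 (0.11 log units; within the scatter), which lies within the scatter, so this assay does not separate compound 1 from compound 3 and either halogen is compatible with a measurable number here.

The compounds shown leave open which part of the entering group matters, as the carbonyl, the ether oxygen and the ring all differ together from the 3-methylphenyl of compound 2; a plain benzoyl or a benzyl group on the same nitrogen would help to separate these parts. They also leave open how the number responds on the aromatic carbon to a group other than a halogen, such as methoxy or a nitrile.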